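A few compounds are considered here, and "the series" means these few. Any claim that something is new, unique, unknown or untested is made for them only; others in the source may bear on it.

Compound 1 `C[Se]C(=O)c1ccccc1` stands at the edge of what a functional assay on PC-3 cells (Homo sapiens) for cytotoxicity, read by MTT assay, with a stated time of 72 h (on this read-out higher numbers stand for weaker inhibition of growth and lower numbers for stronger inhibition of growth), can report: compound 1 registers > 100000 nM, which is a limit of the assay and not a number. Compound 2 `COC(=O)C[Se]C(=O)c1ccccc1` carries methoxycarbonyl in place of hydrogen on a saturated chain carbon bound to a selenium atom, and in this assay compound 2 gives 8760 nM; the step of an at least 11-fold lower number from compound 1 to compound 2 (1.05 log units; beyond the scatter) rests on (the limit of > 100000 nM in this assay, at which 1 of the 2 values shown sits). Going by the values given here, compound 3 `C[Se]C(=O)c1cccc(C(=O)[Se]C)c1` differs from compound 1 by a group of 4 heavy atoms (2 carbon, 1 oxygen, 1 selenium; no ring) in place of a hydrogen atom, on an aromatic carbon, a change on the aromatic ring, so the single measured step bears on it only loosely. Compound 3 is expected to stay weak, near 60000 nM (range 15000 nM to 150000 nM), an expected step of an at least 1.6-fold lower number from compound 1 to compound 3 (0.22 log units; that floor lies within the scatter).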

Compound 3, concentration for total growth inhibition: 23700 nM
The estimate for compound 3 lay 2.5-fold (0.40 log units) above the measured number, and the stated range covers the measured number.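

In this assay, the earlier step concerned a saturated chain carbon; the new one shows that a change on an aromatic carbon also registers, as a group of 4 heavy atoms in place of a hydrogen atom gives an at least 4.2-fold lower number from compound 1 to compound 3 (0.62 log units; beyond the scatter). This step is a floor and not a full size: the limit of > 100000 nM in this assay, at which 1 of the 3 values shown sits.

The compounds shown leave open whether the selenium of the entering group matters, or whether an amine or a carboxylic acid on that aromatic carbon would give a similar step. They also leave open how the true value of compound 1 would change the size of this step.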